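Thymidine ureas: cytotoxicity check on the aryl para substituent

The source may hold more compounds than are shown below. What is called first, only, known or untested is meant among the compounds shown, and "the series" means these compounds.

Compounds 1 and 2 share the thymidine-derived core and differ only in the group on the aromatic carbon of the urea-bound phenyl ring. Compound 1 is `Cc1cn([C@@H]2C[C@H](O)[C@@H](CNC(=O)Nc3ccc(OC4CCOCC4)cc3)O2)c(=O)[nH]c1=O`. In an ADME assay on MRC5 cells (Homo sapiens) for cytotoxicity (on this read-out lower numbers stand for higher toxicity in this test and higher numbers for lower toxicity in this test), compound 1 gives > 50000 nM, which is a limit of the assay and not a number. Compound 2 is `Cc1cn([C@@H]2C[C@H](O)[C@@H](CNC(=O)Nc3ccc(Cc4ccccc4)cc3)O2)c(=O)[nH]c1=O`. In this assay compound 2 gives > 50000 nM, again a limit and not a number. The step that the two limits leave unreadable from compound 1 to compound 2 can therefore not be read as a size, because of the limit of > 50000 nM in this assay, at which 2 of the 2 values shown sit.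

Compound 3 is `Cc1cn([C@@H]2C[C@H](O)[C@@H](CNC(=O)Nc3ccc(OCc4cccc(Cl)c4)cc3)O2)c(=O)[nH]c1=O`. Relative to compound 2 the change is (3-chlorobenzyl)oxy in place of benzyl on an aromatic carbon. Among the compounds with values here, the only measured step on this aryl position, from compound 1 to compound 2, sits at the limit at both ends, so no readable direction is available; neither change has produced a value inside the range of this assay.

For compound 3 in this assay the expectation is a further limit, so the estimated step that the limit leaves unreadable from compound 2 to compound 3 is read as no change beyond scatter. The estimate for compound 3 is 60000 nM, with an expected range from 30000 nM to 150000 nM.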

Compound 3, half-maximal cytotoxic concentration: > 50000 nM
Compound 3: a limit, no number; the forecaster's own chance of this, stated with the estimate: 80%; the middle value lies beyond the limit too.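

No step among compound 1, compound 2 and compound 3 can be read in this assay, because each value is a limit of the assay and not a number: the limit of > 50000 nM in this assay, at which 3 of the 3 values shown sit.

The compounds shown leave open whether any group on this aromatic carbon gives a value inside the range of this assay, and how far apart these three compounds lie.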